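Ethyl in Place of Hydrogen on the Carboxy Oxygen

A few compounds are considered here, and "the series" means these few. Any claim that something is new, unique, unknown or untested is made for them only; others in the source may bear on it.

Compound 3 `Cc1sc(-c2ccc(C(=O)O)cc2)nc1-c1ccccc1` gives 77.8 nM in an assay on isolated protein with retinoic acid receptor beta (Homo sapiens) as the target, read by TR-FRET, with a stated time of 4 h; a higher number here means that more compound is needed for the effect, a lower number that less compound is needed. That is the highest of the three numbers available. Compound 2 `CCOCCOc1nc(-c2ccc(C(=O)O)cc2)sc1C` gives 56.7 nM in this assay, and the step of a 1.4-fold higher number from compound 2 to compound 3 (0.14 log units; within the scatter) lies within the scatter. Compound 1 `CCOC(=O)c1ccc(-c2nc(-c3ccc4c(c3)C(C)(C)CCC4(C)C)c(C)s2)cc1` gives 12.1 nM in this assay, a lower number that lies beyond the scatter. Compound 4 `CCOC(=O)c1ccc(-c2nc(-c3ccccc3)c(C)s2)cc1` differs from compound 3 by ethyl in place of hydrogen on an oxygen next to a carbonyl group. For the measured compounds named here, no measured step isolates this change. Going by the values given here, compound 1 also carries an ethoxycarbonyl group, but it differs from compound 3 in more than one place, so its value shows only that a compound with this group can give a low number in this assay. Among the compounds with values here, the single measured step, a 1.4-fold higher number from compound 2 to compound 3 (0.14 log units; within the scatter), concerns another position and gives no direction here. Compound 4 is therefore expected to give a modestly higher number than compound 3, a step of a 1.9-fold higher number from compound 3 to compound 4 (0.29 log units; within the scatter). The estimate for compound 4 in this assay is 150 nM, with a range from 40 nM to 600 nM.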

Compound 4, half-maximal effective concentration: 136 nM
Compound 4: the middle estimate sits 1.1-fold (0.04 log units) above what was measured; the range from low to high includes it.
By their numbers in this assay, from the lowest: compound 1; then compounds 2, 3 and 4 (each within the scatter of the next, the first and the last beyond it).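

In this assay, ethyl in place of hydrogen on the oxygen next to the carbonyl group gives a 1.7-fold higher number from compound 3 to compound 4 (0.24 log units; within the scatter), so carboxy and ethoxycarbonyl are not told apart on this core. Compound 4 carries the same ethoxycarbonyl group as compound 1, yet compound 4 gives 136 nM while compound 1 gives 12.1 nM in the same assay, so the low number of compound 1 cannot be credited to that group alone. Nothing available explains why the two groups read so closely.

The compounds shown leave open how an amide or a longer ester chain, such as propyl, would read in place of the carboxy group. They also leave open whether the same change gives a similar step on the core of compound 1 or of compound 2.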